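A Bromo Added to a Compound at the Assay Limit

The compounds below may be only part of what the source reports. "The series", "measured", "known", "first", "only" and "open" are said of these compounds alone.

In a functional assay on HL-60 cells (Homo sapiens) for antiproliferative activity, read by CellTiter-Glo, with a stated time of 72 h (on this read-out higher numbers stand for weaker inhibition and lower numbers for stronger inhibition), compound 1 (`CO[C@@H]1[C@H](N(C)c2ncc(-c3c[nH]c4ccc(Cl)cc34)s2)C[C@H]2O[C@]1(C)n1c3ccccc3c3c4c(c5c6ccccc6n2c5c31)C(=O)NC4`) reads > 10000 nM as a limit and not a number. Compound 2 (`CO[C@@H]1[C@H](N(C)c2ncc(-c3c[nH]c4ccc(Br)cc34)s2)C[C@H]2O[C@]1(C)n1c3ccccc3c3c4c(c5c6ccccc6n2c5c31)C(=O)NC4`) reads > 10000 nM in this assay as a limit too. Compound 3 (`COc1ccc2[nH]cc(-c3cnc(N(C)[C@@H]4C[C@H]5O[C@@](C)([C@@H]4OC)n4c6ccccc6c6c7c(c8c9ccccc9n5c8c64)C(=O)NC7)s3)c2c1`) reads > 10000 nM in this assay as a limit as well. Compound 3 therefore stands at the limit of > 10000 nM in this assay, at which 3 of the 3 values shown sit, and has no number of its own.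

Compound 4 (`COc1ccc2[nH]cc(-c3cnc(N(C)[C@@H]4C[C@H]5O[C@@](C)([C@@H]4OC)n4c6ccccc6c6c7c(c8c9cc(Br)ccc9n5c8c64)C(=O)NC7)s3)c2c1`) differs from compound 3 in one place (bromo in place of hydrogen on an aromatic carbon) with bromo in place of hydrogen on an aromatic carbon. Among the measured compounds shown here, three measured steps bear on this only loosely, and none of them is a change from hydrogen to bromo. Bromo in place of chloro is a step that the two limits leave unreadable from compound 1 to compound 2 and methoxy in place of chloro is a step that the two limits leave unreadable from compound 1 to compound 3 while methoxy in place of bromo is a step that the two limits leave unreadable from compound 2 to compound 3 so no size can be read from any of them. With nothing readable to build on, no shift beyond the scatter is expected in this assay in either direction. The expected change is a step that the limit leaves unreadable from compound 3 to compound 4 and this is only a weak estimate. For compound 4 the estimate is 12000 nM with an expected range from 3000 nM to 30000 nM and a report of only a limit is the likeliest outcome.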

Compound 4, half-maximal inhibitory concentration: > 10000 nM
Compound 4: no number, only a limit; the forecaster's own chance of this, stated with the estimate: 85%; the middle value does not contradict the limit.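

In this assay compound 4 gives > 10000 nM, which is a limit and not a number. Compound 3 also carries only a limit, so no step can be read for bromo in place of hydrogen between compound 3 and compound 4. All the compounds shown share one reading: the limit of > 10000 nM in this assay, at which 4 of the 4 values shown sit. They leave open how large any of these changes is in this assay.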